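Lengthening the link in compound 2 by one methyl carbon

This account rests on a few compounds, and the source may have more. Where it says the series, first, only, none or still open, it means among the compounds named here.

compound 1 `CC(C)[C@H](C[C@H]1OC(=O)NC1=O)c1ccc(-c2ccc3cccc(F)c3c2)[nH]c1=O`: 24400 nM
compound 2 `CC(C)[C@@H](c1ccc(-c2ccc3cccc(F)c3c2)[nH]c1=O)[C@H]1OC(=O)NC1=O`: 5400 nM

In a physicochemical assay for solubility, measured as kinetic solubility, at pH 2 (a lower number here means a less soluble compound, a higher number a more soluble compound), compound 2 is the lower of the two measured compounds at 5400 nM. The next compound, compound 3 `CC(C)[C@H](C[C@@H]1OC(=O)NC1=O)c1ccc(-c2ccc3cccc(F)c3c2)[nH]c1=O`, changes the group on the saturated chain carbon: (2,4-dioxo-1,3-oxazolidin-5-yl)methyl in place of 2,4-dioxo-1,3-oxazolidin-5-yl on a saturated chain carbon bound to an aromatic carbon and a saturated chain carbon. Among the measured compounds shown here, one measured step bears on this, the same swap of groups run the other way: a 4.5-fold lower number from compound 1 to compound 2 (0.65 log units; beyond the scatter). That step is modest but beyond the scatter. For the measured compounds named here, it is only a single pair, so a rise of similar or somewhat smaller size is expected here, with wide uncertainty. The estimate is a 3.1-fold higher number from compound 2 to compound 3 (0.50 log units; beyond the scatter). For compound 3 the expected value is 17000 nM, with an estimated range of 7000 nM to 40000 nM.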

Compound 3, solubility: 25100 nM
Beside the measured number, compound 3's estimate is 1.5-fold (0.17 log units) below it; the measured number falls inside the stated range.
By their numbers in this assay, from the lowest: compound 2; then compounds 1 and 3 (each within the scatter of the next).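

In this assay the (2,4-dioxo-1,3-oxazolidin-5-yl)methyl group now appears with both drawn configurations at the saturated ring carbon, and the step to it holds for the second one: a 4.6-fold higher number from compound 2 to compound 3 (0.67 log units; beyond the scatter). Changing that configuration leaves the reading within the scatter, with a 1.0-fold higher number from compound 1 to compound 3 (0.01 log units; within the scatter), and this pair isolates that one feature: the fact that compounds 1 and 3 differ only in the configuration as drawn.

As far as these compounds go, whether the 2,4-dioxo-1,3-oxazolidin-5-yl group is equally insensitive to its ring configuration stays open. So does how a longer chain or a carboxylic acid in place of the ring would read.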